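Chloro in place of fluoro on compound 2

This account rests on a few compounds, and the source may have more. Where it says the series, first, only, none or still open, it means among the compounds named here.

Among the measured compounds shown here, in a functional assay on MCF7 cells (Homo sapiens) for antiproliferative activity, read by MTT assay, with a stated time of 48 h (on this read-out lower numbers stand for stronger inhibition and higher numbers for weaker inhibition), only two compounds have numbers so far. Compound 1 (`O=C(NS(=O)(=O)c1ccc(F)cc1)c1cncc(Br)c1`) gives 980 nM on this read-out. Compound 2 (`O=C(NS(=O)(=O)c1ccc(F)cc1)c1cccnc1Cl`) gives 12500 nM as the higher of the two numbers, and its gap to compound 1 lies beyond the scatter. These two compounds differ in more than one place, so their gap isolates no single change.

Compound 3 (`O=C(NS(=O)(=O)c1ccc(Cl)cc1)c1cccnc1Cl`) has not been measured yet. It keeps everything in compound 2 except one substituent, with chloro in place of fluoro on an aromatic carbon, para to a large group (chloro in place of fluoro on an aromatic carbon). For the measured compounds named here, no measured pair shows this swap, so the expectation rests only on how small the structural change is. In this assay an estimated 1.5-fold lower number from compound 2 to compound 3 (0.17 log units; within the scatter) is expected as a modest move toward a lower number, and it may well stay within the scatter. For compound 3 the expected value is 8500 nM with an estimated range from 2800 nM to 25000 nM in this series.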

Compound 3, half-maximal inhibitory concentration: 10200 nM
For compound 3 the middle estimate is 1.2-fold (0.08 log units) below the measured one; measured number inside the range.
By their numbers in this assay, from the lowest: compound 1; then compounds 3 and 2 (each within the scatter of the next).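

In this assay the swap of fluoro for chloro on an aromatic carbon, para to a large group, gives a 1.2-fold lower number from compound 2 to compound 3 (0.09 log units; within the scatter) and so compound 2 and compound 3 cannot be told apart on this read-out. Among the compounds shown here, this is the first step that isolates a single change, since the earlier pair differs in more than one place and could not speak to any one position. At this position, on the background of compound 2, fluoro and chloro read alike, while compound 1 differs from both compounds in more than one place and falls outside this step. Nothing at hand gives a reason for this result.

Only two halogens are shown at this position, so it stays open whether an amine, a methoxy group or a carboxylic acid there would separate from compound 2 beyond the scatter. The bromo and chloro substituents at the other end of the molecule also remain unresolved, as no single-place step among these compounds touches them.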